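A (2-hydroxyethoxy)methyl group replaces 1-hydroxy-1-methylethyl on the shared core

This account rests on a few compounds, and the source may have more. Where it says the series, first, only, none or still open, it means among the compounds named here.

Of the compounds shown here, three sharing one core have been measured in an ADME assay on the whole organism (Mus musculus, strain C57BL/6J) for pharmacokinetics, with a stated time of 24 h, at a dose of 2 mg/kg by the intravenous route; a lower number here means slower removal, a higher number faster removal of the compound. Compound 1 `CCCCOc1nc(OCC(C)(C)O)c(-c2ccc(S(C)(=O)=O)cc2)cc1CO`, carrying hydroxymethyl, gives 101 mL/min/kg. Compound 2 `CCCCOc1nc(OCC(C)(C)O)c(-c2ccc(S(C)(=O)=O)cc2)cc1C(C)O`, with one methyl added on the carbon bearing that hydroxyl, gives 48.2 mL/min/kg. Compound 3 `CCCCOc1nc(OCC(C)(C)O)c(-c2ccc(S(C)(=O)=O)cc2)cc1C(C)(C)O`, carrying 1-hydroxy-1-methylethyl, gives 58.8 mL/min/kg.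

Compound 3 thus stands close to both others, as shown by a 1.7-fold lower number from compound 1 to compound 3 (0.23 log units; within the scatter) and by a 1.2-fold higher number from compound 2 to compound 3 (0.09 log units; within the scatter). Only a 2.1-fold lower number from compound 1 to compound 2 (0.32 log units; beyond the scatter) goes beyond the scatter, and modestly so.

Compound 4 `CCCCOc1nc(OCC(C)(C)O)c(-c2ccc(S(C)(=O)=O)cc2)cc1COCCO` differs from compound 3 by (2-hydroxyethoxy)methyl in place of 1-hydroxy-1-methylethyl on an aromatic carbon, ortho to a butoxy group. Among the measured compounds shown here, no measured step makes this exact exchange, so the three steps above, all at this same place, are the only guide, and all are small. In compound 4, as in compound 1 at 101 mL/min/kg, the carbon bound to the aromatic carbon carries no methyl, which tilts the expectation slightly toward a higher number. The expected size is a 1.2-fold higher number from compound 3 to compound 4 (0.09 log units; within the scatter), and no step beyond the scatter is anticipated. Compound 4 is estimated at 72 mL/min/kg, with an expected range of 36 mL/min/kg to 130 mL/min/kg.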

Compound 4, clearance: 55.4 mL/min/kg
The estimate for compound 4 lay 1.3-fold (0.11 log units) above the measured number; the measured number falls inside the stated range.
By their numbers in this assay, from the lowest: compounds 2, 4, 3 and 1 (each within the scatter of the next, the first and the last beyond it).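

In this assay, the exchange at this place, ortho to a butoxy group, gives a 1.1-fold lower number from compound 3 to compound 4 (0.03 log units; within the scatter), and the step from the 1-hydroxyethyl compound gives a 1.1-fold higher number from compound 2 to compound 4 (0.06 log units; within the scatter), so the new group cannot be told apart from either branched hydroxyalkyl group. The carbon bound to the aromatic ring carries no methyl in compound 4, as in compound 1, and the step between those two reads a 1.8-fold lower number from compound 1 to compound 4 (0.26 log units; within the scatter), which is also within the scatter; compound 4 therefore cannot be separated from any of the three earlier compounds, and a methyl-free carbon at this place does not by itself set a compound apart from compounds 2 and 3. No measurement shown here offers an explanation for where compound 4 falls.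

The compounds shown leave open whether the terminal hydroxyl of the (2-hydroxyethoxy)methyl group matters to clearance, for which a methoxyethoxymethyl group would be the direct comparison. They also leave open whether an amine or a carboxylic acid at this same place, or any change to the butoxy or 2-hydroxy-2-methylpropoxy groups, would move clearance beyond the scatter.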